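Trading a hexyl chain for hydroxymethyl on the triazole

A few compounds are considered here, and "the series" means these few. Any claim that something is new, unique, unknown or untested is made for them only; others in the source may bear on it.

Measured compounds:
compound 1 `COc1nc2ccc(Br)cc2cc1C(c1ccccc1)n1cc(C2CC2)nn1`: 21.8%
compound 2 `CCCCc1cn(C(c2ccccc2)c2cc3cc(Br)ccc3nc2OC)nn1`: 5.46%
compound 3 `CCCCCCc1cn(C(c2ccccc2)c2cc3cc(Br)ccc3nc2OC)nn1`: 6.08%

In an ADME assay on PANC-1 cells (Homo sapiens) for cytotoxicity, read by sulforhodamine B assay, with a stated time of 48 h, tested at 10 uM (on this read-out higher numbers stand for more inhibition at the one concentration tested (going by the name of the read-out) and lower numbers for less inhibition), compound 3 sits second highest of the three, with compound 2 within the scatter of it and compound 1 clearly higher. Compound 4 `COc1nc2ccc(Br)cc2cc1C(c1ccccc1)n1cc(CO)nn1` differs from compound 3 by hydroxy in place of pentyl on a saturated chain carbon bound to an aromatic carbon. Among the measured compounds shown here, two steps bear on this. The step of a number 16.3 percentage points lower from compound 1 to compound 2 (beyond the scatter) and the step of a number 15.7 percentage points lower from compound 1 to compound 3 (beyond the scatter) show that swapping cyclopropyl for a straight chain cost inhibition, while a number 0.6 percentage points higher from compound 2 to compound 3 (within the scatter) shows chain length made no difference. For the measured compounds named here, no measured step covers a hydroxy group. Going by the values given here, because compound 1, the one with the smallest group, gave 21.8%, a move toward a small group is expected to raise inhibition modestly, so a number 6.9 percentage points higher from compound 3 to compound 4 (within the scatter) is estimated. Compound 4 is therefore expected to give 13%, between 0% and 30%.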

Compound 4, a percentage reported as inhibition, at one concentration (the size of the read-out at that concentration, not a potency): 15%
Estimate against measurement, compound 4: 2 percentage points below; the range from low to high includes it.
By their numbers in this assay, from the lowest: compounds 2, 3, 4 and 1 (each within the scatter of the next, the first and the last beyond it).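

In this assay, hydroxymethyl at this position gives no step beyond the scatter from any of the other groups (a number 8.9 percentage points higher from compound 3 to compound 4 (within the scatter)) (a number 9.5 percentage points higher from compound 2 to compound 4 (within the scatter)) (a number 6.8 percentage points lower from compound 1 to compound 4 (within the scatter)). Compound 4 therefore cannot be separated from the butyl and hexyl compounds or from the cyclopropyl compound, even though those chains and cyclopropyl do differ beyond the scatter. Its hydroxy group thus falls on neither side of that gap. Still open, going by these compounds, is how an amine, a carboxylic acid or a longer chain ending in hydroxy would read here. No measurement shown accounts for these numbers.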